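Piperidine substituent swap on the shared core

The source may hold more compounds than are shown below. What is called first, only, known or untested is meant among the compounds shown, and "the series" means these compounds.

Compound 2 `CC(C(=O)NCc1ccc(C(F)(F)F)nc1N1CCC(C)(C)CC1)c1ccc(NS(C)(=O)=O)c(F)c1` gives 8 nM in a functional assay on CHO-K1 cells for antagonist activity at transient receptor potential cation channel subfamily V member 1 (Homo sapiens), read by FLIPR (a lower number here means a stronger inhibitor, a higher number a weaker inhibitor), the lowest of the two numbers recorded so far; compound 1 `CC(C(=O)NCc1ccc(C(F)(F)F)nc1N(C)c1ccccc1)c1ccc(NS(C)(=O)=O)c(F)c1` gives 57.4 nM in the same assay. Among the measured compounds shown here, the one measured step, a 7.2-fold lower number from compound 1 to compound 2 (0.86 log units; beyond the scatter), concerns the exchange of methyl(phenyl)amino for 4,4-dimethylpiperidin-1-yl on an aromatic carbon.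

Compound 3 `CC(C(=O)NCc1ccc(C(F)(F)F)nc1N1CCC(C(F)(F)F)CC1)c1ccc(NS(C)(=O)=O)c(F)c1` keeps the piperidine ring of compound 2 and alters only its substitution: 4-(trifluoromethyl)piperidin-1-yl in place of 4,4-dimethylpiperidin-1-yl on an aromatic carbon.

For the measured compounds named here, no measured step touches the substituent on the piperidine ring itself. The step from compound 1 to compound 2 shows that the group on this aromatic carbon matters for this assay, but it does not tell how two piperidines carrying different substituents compare. With both compounds keeping a saturated six-membered ring with one hetero atom, a step within the scatter is the plainest expectation, with no direction favoured. Compound 3 is therefore expected to give about 12 nM in this assay, within 4 nM to 40 nM. The expected step is a 1.5-fold higher number from compound 2 to compound 3 (0.18 log units; within the scatter), which stays inside the scatter.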

Compound 3, half-maximal inhibitory concentration: 31 nM
Compound 3: the middle estimate sits 2.6-fold (0.41 log units) below what was measured, and the stated range covers the measured number.
By their numbers in this assay, from the lowest: compound 2; then compounds 3 and 1 (each within the scatter of the next).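

In this assay the substituent on the piperidine ring itself proves to matter: a 3.9-fold higher number from compound 2 to compound 3 (0.59 log units; beyond the scatter) is the result of 4-(trifluoromethyl)piperidin-1-yl replacing 4,4-dimethylpiperidin-1-yl, even though the six-membered ring stays the same. The piperidine ring alone therefore does not carry the gain seen with compound 2: with 4-(trifluoromethyl)piperidin-1-yl on this aromatic carbon, a 1.9-fold lower number from compound 1 to compound 3 (0.27 log units; within the scatter) stays within the scatter, so this piperidine cannot be told apart from methyl(phenyl)amino at this position. Nothing available here bears on the reason for the difference between the two piperidine substituents.

The compounds shown leave open how an unsubstituted piperidin-1-yl, a 4-methylpiperidin-1-yl or a morpholin-4-yl group would compare on this aromatic carbon, and so whether the gap between compound 2 and compound 3 follows from the two methyl groups, from the trifluoromethyl group, or from both. They also leave open whether the two piperidine substituents keep the same order when a chlorine atom or a nitrile stands in place of the trifluoromethyl group on the aromatic ring of the shared core.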